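The compounds below may be only part of what the source reports. "The series", "measured", "known", "first", "only" and "open" are said of these compounds alone.

Measured compounds:
- compound 1 `COc1ccc(C2=C(c3cc(OC)c(OC)c(OC)c3)C(=O)C(OC(C)=O)C2)cc1F`: 39.5 ug/mL
- compound 2 `COc1ccc(C2=C(c3cc(OC)c(OC)c(OC)c3)CC(O[SiH2]C(C)(C)C)C2=O)cc1[N+](=O)[O-]`: > 100 ug/mL
- compound 3 `COc1ccc(OC)c(C2=C(c3cc(OC)c(OC)c(OC)c3)C(=O)CC2O[SiH2]C(C)(C)C)c1`: > 100 ug/mL

In an ADME assay on MIA PaCa-2 cells (Homo sapiens) for cytotoxicity, read by MTT assay, with a stated time of 72 h (on this read-out higher numbers stand for weaker inhibition and lower numbers for stronger inhibition), compound 1 gives 39.5 ug/mL. Compound 2 reaches only a limit of the assay in this assay, > 100 ug/mL. Compound 3 likewise reaches only a limit in this assay, > 100 ug/mL. Among the compounds with values here, compound 1 therefore holds the only number in the set, and it stands apart from the limit of > 100 ug/mL in this assay, at which 2 of the 3 values shown sit.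

Compound 4 `COc1ccc(C2=C(c3cc(OC)c(OC)c(OC)c3)C(=O)C(OC(C)=O)C2)cc1O` has not yet been measured. It differs from compound 1 in one place: hydroxy in place of fluoro on an aromatic carbon. The change sits on an aromatic carbon of a six-membered aromatic ring of carbon only, ortho to a methoxy group and meta to a large group; seen one bond further out, the 3-fluoro-4-methoxyphenyl of compound 1 becomes a 3-hydroxy-4-methoxyphenyl in compound 4.

Within the data shown here, no measured pair differs in one place, so no measured step guides the expectation. Compound 4 is expected to stay close to compound 1, with the step of a 1.1-fold higher number from compound 1 to compound 4 (0.06 log units; within the scatter) estimated to lie within the scatter. In this assay compound 4 is expected to give about 45 ug/mL, within a range from 15 ug/mL to 120 ug/mL.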

Compound 4, half-maximal inhibitory concentration: 18.5 ug/mL
Compound 4: the middle estimate sits 2.4-fold (0.39 log units) above what was measured; measured number inside the range.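

In this assay, within the data shown here, hydroxy in place of fluoro on the aromatic carbon gives a 2.1-fold lower number from compound 1 to compound 4 (0.33 log units; beyond the scatter), the first step that can be read at this position. The 3-hydroxy-4-methoxyphenyl of compound 4 therefore inhibits more strongly than the 3-fluoro-4-methoxyphenyl of compound 1, so this position responds to the change, though the step is modest. The entering hydroxy brings one hydrogen-bond donor and one hydrogen-bond acceptor, where fluoro is counted with neither, but one pair cannot show whether either accounts for the step.

Steps to compound 2 and compound 3 cannot be read, and each of these compounds stands at a limit of the assay: the limit of > 100 ug/mL in this assay, at which 2 of the 4 values shown sit. Going by these compounds, whether an amine or a carboxylic acid at this position would go further than hydroxy stays open.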